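Swapping 1-phenylethyl for 2-aminoethyl on a shared core

The compounds below may be only part of what the source reports. "The series", "measured", "known", "first", "only" and "open" are said of these compounds alone.

Three compounds built on a shared core have so far entered a functional assay on MCF7 cells (Homo sapiens) for cytotoxicity, read by MTT assay, with a stated time of 72 h; on this read-out lower numbers stand for stronger inhibition and higher numbers for weaker inhibition. Compound 1 (`CS(=O)(=O)Oc1c(C(=O)NCc2ccc(F)cc2)nc(Br)c2cccnc12`) stands at "not determined" (no result reported). Among the measured compounds shown here, compound 2 (`O=C(NCCCNc1c(C(=O)NCc2ccc(F)cc2)nc(Br)c2cccnc12)c1ccccc1`) gives 2000 nM, the only real number in the set. Compound 3 (`C[C@H](Nc1c(C(=O)NCc2ccc(F)cc2)nc(Br)c2cccnc12)c1ccccc1`) stands at "not determined" (no result reported), so compound 3 has no place on the scale and cannot be ranked against compound 2.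

The next compound, compound 4 (`NCCNc1c(C(=O)NCc2ccc(F)cc2)nc(Br)c2cccnc12`), keeps the core of compound 3 and changes a single group: 2-aminoethyl in place of 1-phenylethyl on a nitrogen on an aromatic ring. Put simply, 2-aminoethyl sits in place of 1-phenylethyl on a nitrogen on an aromatic ring.

With no number for compound 3, the size of this step cannot be measured from its starting point. For the measured compounds named here, the only anchor is compound 2 at 2000 nM, a single value that supports only a cautious forecast. In this assay, the expectation is therefore no step beyond the usual scatter from that anchor, and no firm direction can be claimed. Much wider outcomes remain possible, so the range is kept broad. For compound 4 the estimated value is 2500 nM, with an expected range from 500 nM to 12000 nM.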

Compound 4, half-maximal inhibitory concentration: 6000 nM
Estimate against measurement, compound 4: 2.4-fold (0.38 log units) below; measured number inside the range.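

Compound 3 has no number in this assay, so the change from 1-phenylethyl to 2-aminoethyl on the nitrogen cannot be read as a step. The readable comparison is a 3.0-fold higher number from compound 2 to compound 4 (0.48 log units; beyond the scatter), with amino in place of benzamidomethyl on a saturated chain carbon, two bonds along the chain from a nitrogen on an aromatic ring; this modest shift lies beyond the usual scatter and means weaker inhibition once the benzamidomethyl end is gone. Nothing measured here gives a reason for this step.

The two numbers leave open whether the benzene ring, the amide or both of these parts of the benzamidomethyl group go with the stronger inhibition. They also leave open how a dimethylamino group, a hydroxyl group or a carboxylic acid in place of the amino group at the end of the chain would read in this assay, and whether a longer chain would move the number in either direction.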